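From Carbamoyl to an Ethoxycarbonylethenyl Chain on Compound 3

The source may report more compounds than this note shows. Statements on the series, on what has been measured and on what is new or still open speak of the compounds shown alone.

Of the compounds shown here, three have been tested in a functional assay on cells (Platelet, Homo sapiens) for inhibition; on this read-out lower numbers stand for stronger inhibition and higher numbers for weaker inhibition. Compound 1 `CCOC(=O)c1ccc(-c2nn(Cc3ccccc3F)c3ccccc23)cc1` reaches only the limit of this assay, giving > 10000 nM. Compound 2 `CCOC(=O)c1ccc(-c2nn(Cc3cccc(OC)c3)c3ccccc23)cc1` likewise sits at a limit, giving > 10000 nM. The step that the two limits leave unreadable from compound 1 to compound 2 therefore cannot be read. Compound 3 `NC(=O)c1ccc(-c2nn(Cc3ccccc3)c3ccccc23)cc1` also gives only a limit, > 10000 nM, so it can be placed no more closely than the limit of > 10000 nM in this assay, at which 3 of the 3 values shown sit. Compound 4 `CCOC(=O)/C=C/c1ccc(-c2nn(Cc3ccccc3)c3ccccc23)cc1` differs from compound 3 by 2-(ethoxycarbonyl)ethenyl in place of carbamoyl on an aromatic carbon, on an aromatic carbon para to a large group. Going by the values given here, no measured step bears on this change; the only step available is itself unreadable. Compound 4 is expected to remain near the same limit, with an estimated step that the limit leaves unreadable from compound 3 to compound 4. Compound 4 is estimated at 15000 nM, with a range from 3000 nM to 60000 nM.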

Compound 4, half-maximal inhibitory concentration: > 10000 nM
Compound 4 gave a limit, no number (the forecaster's own chance of this, stated with the estimate: 75%); the middle value does not contradict the limit.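

Compound 3 and compound 4 each give only a limit, not a number, so no step between them can be read: the limit of > 10000 nM in this assay, at which 4 of the 4 values shown sit.

The compounds shown leave open which change to the shared core, if any, would give a measurable value in this assay.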